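The source may report more compounds than this note shows. Statements on the series, on what has been measured and on what is new or still open speak of the compounds shown alone.

Measured in a functional assay on DLD-1 cells (Homo sapiens) for antiproliferative activity, read by CellTiter-Glo, with a stated time of 72 h; on this read-out higher numbers stand for weaker inhibition and lower numbers for stronger inhibition:
- compound 1, `Cc1cc(C)c(S(=O)(=O)N2CCC(N3CCC(C)CC3)CC2)c(C)c1`: 0.03 nM
- compound 2, `C#CCCC(=O)CC1CCN(C2CCN(S(=O)(=O)c3c(C)cc(C)cc3C)CC2)CC1`: 3 nM
- compound 3, `Cc1cc(C)c(S(=O)(=O)N2CCC(N3CCC(O)CC3)CC2)c(C)c1`: 106 nM

Compound 3 carries the highest number of the three, that is the weakest inhibition in this set. The steps leading to it are both large: a 3500-fold higher number from compound 1 to compound 3 (3.55 log units; beyond the scatter) and a 35-fold higher number from compound 2 to compound 3 (1.55 log units; beyond the scatter). In each, a carbon substituent on the saturated ring carbon gave way to hydroxy and the number rose sharply.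

Compound 4, `Cc1cc(C)c(S(=O)(=O)N2CCC(N3CCC(Cc4ccccc4F)CC3)CC2)c(C)c1`, reverses that type of change: 2-fluorobenzyl in place of hydroxy on a saturated ring carbon. The two steps that bear on it, from compound 1 and from compound 2 to compound 3, both point the same way, so the replacement of hydroxy by a carbon group is expected to lower the number strongly, in this assay by about a 110-fold lower number from compound 3 to compound 4 (2.03 log units; beyond the scatter). Compound 4 is therefore estimated at 1 nM, with a range of 0.1 nM to 10 nM.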

Compound 4, half-maximal inhibitory concentration: 74 nM
Beside the measured number, compound 4's estimate is 74-fold (1.87 log units) below it, and the stated range ends below it.
By their numbers in this assay, from the lowest: compound 1; then compound 2; then compounds 4 and 3 (each within the scatter of the next).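

In this assay, a carbon group on this saturated ring carbon does not by itself give a low number: a 1.4-fold lower number from compound 3 to compound 4 (0.16 log units; within the scatter) leaves 2-fluorobenzyl and hydroxy within the scatter of each other. The methyl of compound 1 stands apart, with a 2500-fold higher number from compound 1 to compound 4 (3.39 log units; beyond the scatter), and the ((but-3-yn-1-yl)carbonyl)methyl of compound 2 also gives a lower number, with a 25-fold higher number from compound 2 to compound 4 (1.39 log units; beyond the scatter), so carbon groups at this position do not share one outcome. No available evidence accounts for this result.

Open, from the compounds shown here alone, is where ethyl, unsubstituted benzyl or an amine on the same ring carbon would fall relative to compound 1 and compound 4.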